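Methylamino in Place of Sulfonate on the Core of Compound 1

A few compounds are considered here, and "the series" means these few. Any claim that something is new, unique, unknown or untested is made for them only; others in the source may bear on it.

Compound 1, `CS(=O)(=O)Oc1c(C(=O)NCc2ccc(F)cc2)nc(Br)c2cccnc12`, was tested in a functional assay on HCT-116 cells (Homo sapiens) for cytotoxicity, read by MTT assay, with a stated time of 72 h; a lower number here means a stronger inhibitor, a higher number a weaker inhibitor. In this assay compound 1 gives only a limit of the assay, > 20000 nM, and not a number. Among the measured compounds shown here, that limit is the only point where compound 1 stands, as the limit of > 20000 nM in this assay, at which 1 of the 2 values shown sits, records. For the measured compounds named here, compound 2, `N[C@H]1CC[C@H](Nc2c(C(=O)NCc3ccc(Oc4ccccc4)cc3)nc(Br)c3cccnc23)CC1`, belongs to the same series, but in this assay compound 2 has "not determined" (no result reported), so no step can be drawn from it. Compound 3, `CNc1c(C(=O)NCc2ccc(F)cc2)nc(Br)c2cccnc12`, is the compound still to be measured. It differs from compound 1 in a single place: methylamino in place of (methylsulfonyl)oxy on an aromatic carbon. Going by the values given here, no step between two measured compounds exists in this assay, so the size and direction of this change can only be expected, not read off. The account expects the step to lean toward a stronger inhibitor, while accepting that it may remain within the scatter around the limit. Compound 3 is estimated at 6000 nM, with a range from 600 nM to 20000 nM, which corresponds to an expected step of an at least 3.3-fold lower number from compound 1 to compound 3 (0.52 log units; beyond the scatter).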

Compound 3, half-maximal inhibitory concentration: > 20000 nM
Compound 3 ended at the assay's limit; the forecaster's own chance of this, stated with the estimate: 40%; middle value at least 3.3-fold (0.52 log units) from the limit.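

In this assay compound 3 gives > 20000 nM, a limit of the assay and not a number. Compound 1 stands at a limit as well, so no step from it to compound 3 can be read: the limit of > 20000 nM in this assay, at which 2 of the 3 values shown sit.

The compounds shown leave open whether methylamino in place of (methylsulfonyl)oxy on the shared core changes the result in this assay at all.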